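Arginase-1 series: aminoethyl against heteroaryl substituents

The source may report more compounds than this note shows. Statements on the series, on what has been measured and on what is new or still open speak of the compounds shown alone.

Measured compounds:
compound 1 `C[C@H](N)CN1C[C@H](CCCB(O)O)[C@](N)(C(=O)O)C1` — 7.7 nM
compound 2 `N[C@@]1(C(=O)O)CN(Cc2cncs2)C[C@@H]1CCCB(O)O` — 360 nM

In an assay for inhibition of arginase-1 (Homo sapiens), read by colorimetric assay, with a stated time of 60 min, in the presence of a further agent that is not named here (on this read-out higher numbers stand for weaker inhibition and lower numbers for stronger inhibition), compound 1 gives 7.7 nM, the lowest number of the two measured, and compound 2 gives 360 nM. Going by the values given here, the one measured step, a 47-fold higher number from compound 1 to compound 2 (1.67 log units; beyond the scatter), puts 1,3-thiazol-5-yl in place of 1-aminoethyl on a saturated chain carbon bound to an amine nitrogen in a ring.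

Compound 3 `N[C@@]1(C(=O)O)CN(Cc2ncccc2F)C[C@@H]1CCCB(O)O` is not yet measured. It differs from compound 1 as follows: 3-fluoropyridin-2-yl in place of 1-aminoethyl on a saturated chain carbon bound to an amine nitrogen in a ring. Again a ring with one hetero atom replaces the 1-aminoethyl group at the same place, so the step from compound 1 to compound 2 is the one that bears on it, and it was large. A loss of similar size is therefore expected, as a 39-fold higher number from compound 1 to compound 3 (1.59 log units; beyond the scatter). Compound 3 is estimated at 300 nM, within 80 nM to 1200 nM.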

Compound 3, half-maximal inhibitory concentration: 670 nM
Compound 3: the middle estimate sits 2.2-fold (0.35 log units) below what was measured; low and high end bracket the measured number.
By their numbers in this assay, from the lowest: compound 1; then compounds 2 and 3 (each within the scatter of the next).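

In this assay there is an 87-fold higher number from compound 1 to compound 3 (1.94 log units; beyond the scatter) and so the large loss seen with 1,3-thiazol-5-yl is not confined to that ring; it also appears with a six-membered aromatic ring carrying fluorine. Between the two rings there is a 1.9-fold higher number from compound 2 to compound 3 (0.27 log units; within the scatter) and this lies within the scatter, so this assay does not separate 3-fluoropyridin-2-yl from 1,3-thiazol-5-yl at this position. No available measurement explains either step.

Open, as far as these compounds go, is whether the amine of the 1-aminoethyl group or its carbon chain accounts for the low number of compound 1, a question that a plain ethyl group at this place would address. Also open, from the compounds shown here alone, is whether an aminomethyl group on a pyridine ring would recover the loss seen with the rings.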